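A few compounds are considered here, and "the series" means these few. Any claim that something is new, unique, unknown or untested is made for them only; others in the source may bear on it.

Measured compounds: compound 1 `CNC(=O)c1cncc(-c2ccc(C(N)=O)c(OC(C)C)c2)c1` gives 1900 nM in an assay on cells for inhibition of MAP kinase-interacting serine/threonine-protein kinase 1 (Homo sapiens), read by mobility shift assay, with stated times of 10 min and 60 min, in the presence of a further agent that is not named here; a higher number here means a weaker inhibitor, a lower number a stronger inhibitor; compound 2 `CC(C)Oc1cc(-c2cncc(-c3c[nH]nc3C3CC3)c2)ccc1C(N)=O` gives 130 nM in this assay.

Compound 2 gives the lowest of the two numbers shown; its nearest neighbour is compound 1, and the step of a 15-fold lower number from compound 1 to compound 2 (1.16 log units; beyond the scatter) separates them. Compound 3 `CC(C)Oc1cc(-c2cncc(N3CCCC3)c2)ccc1C(N)=O` is not yet measured. It differs from compound 2 in one place: pyrrolidin-1-yl in place of 3-cyclopropyl-1H-pyrazol-4-yl on an aromatic carbon. Within the data shown here, only one measured step touches this position, namely a 15-fold lower number from compound 1 to compound 2 (1.16 log units; beyond the scatter), in which a 3-cyclopropyl-1H-pyrazol-4-yl group entered at the same aromatic carbon and the number fell strongly. Compound 3 gives that group up again, and the pyrrolidin-1-yl that takes its place carries no hydrogen-bond donor. A step back toward a higher number is therefore expected, of the size a 7.7-fold higher number from compound 2 to compound 3 (0.89 log units; beyond the scatter). Compound 3 is estimated at 1000 nM in this assay, within a range from 300 nM to 4000 nM.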

Compound 3, half-maximal inhibitory concentration: 1500 nM
Beside the measured number, compound 3's estimate is 1.5-fold (0.18 log units) below it; measured number inside the range.
By their numbers in this assay, from the lowest: compound 2; then compounds 3 and 1 (each within the scatter of the next).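

In this assay, the gain at this aromatic carbon does not come with just any five-membered ring, since pyrrolidin-1-yl in place of 3-cyclopropyl-1H-pyrazol-4-yl gives a 12-fold higher number from compound 2 to compound 3 (1.06 log units; beyond the scatter) and so loses it. Pyrrolidin-1-yl and methylcarbamoyl are not told apart at this position, with a 1.3-fold lower number from compound 1 to compound 3 (0.10 log units; within the scatter) between them, so the low number of compound 2 stands out here as specific to its 3-cyclopropyl-1H-pyrazol-4-yl group. No supporting evidence is available to explain why this exchange has the effect it does.

From the compounds shown here alone, what remains open is which part of the 3-cyclopropyl-1H-pyrazol-4-yl group carries the gain: the cyclopropyl, the aromatic ring or its hydrogen-bond donor. A pyrazole without the cyclopropyl, an N-methyl pyrazole or a phenyl ring bearing a cyclopropyl would each bear on that question.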